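Replacing the methanesulfonamido group of compound 2

The source may hold more compounds than are shown below. What is called first, only, known or untested is meant among the compounds shown, and "the series" means these compounds.

Compound 2 `Cc1c(F)c(Oc2cccc(NS(C)(=O)=O)c2)nc(Oc2cccc(C(=N)N)c2)c1F` gives 1900 nM in an assay on isolated protein for inhibition of serine protease 1 (Bos taurus) (a lower number here means a stronger inhibitor, a higher number a weaker inhibitor), and holds the lowest of the two numbers in hand. Compound 3 `Cc1c(F)c(Oc2cccc(C(=N)N)c2)nc(Oc2cccc(C(=O)C(C)C)c2)c1F` gives 3800 nM; the step of a 2.0-fold higher number from compound 2 to compound 3 (0.30 log units; within the scatter) stays within the scatter. Compound 1 `Cc1c(F)c(Oc2cccc(C(=N)N)c2)nc(Oc2cccc([N+](=O)[O-])c2)c1F` reports only a limit, > 5000 nM, in this assay. For the measured compounds named here, the step of an at least 2.6-fold lower number from compound 1 to compound 2 (0.42 log units; beyond the scatter) is the one change at this position that clears the scatter.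

Compound 4 `Cc1c(F)c(Oc2cccc(C(=N)N)c2)nc(Oc2cccc([S+]([O-])N(C)C)c2)c1F` differs from compound 2 by a group of 5 heavy atoms (2 carbon, 1 nitrogen, 1 oxygen, 1 sulfur; no ring) in place of a group of 5 heavy atoms (1 carbon, 1 nitrogen, 2 oxygen, 1 sulfur; no ring), on an aromatic carbon. Going by the values given here, no measured step repeats this exchange; the two neighbouring substituents frame compound 2 only through a 2.0-fold higher number from compound 2 to compound 3 (0.30 log units; within the scatter) and an at least 2.6-fold lower number from compound 1 to compound 2 (0.42 log units; beyond the scatter), so no step beyond the scatter is expected, with a slight drift upward the more likely side. Compound 4 is expected to give 2600 nM (range 900 nM to 7500 nM), an expected step of a 1.4-fold higher number from compound 2 to compound 4 (0.14 log units; within the scatter).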

Compound 4, inhibition constant: 2400 nM
Beside the measured number, compound 4's estimate is 1.1-fold (0.03 log units) above it; low and high end bracket the measured number.
By their numbers in this assay, from the lowest: compounds 2, 4 and 3 (each within the scatter of the next). At a limit, above all of these: compound 1.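

In this assay, the hydrogen-bond donor of methanesulfonamido is not required at this position: the entering group has none, and the result is a 1.3-fold higher number from compound 2 to compound 4 (0.10 log units; within the scatter). Against isopropylcarbonyl the same group gives a 1.6-fold lower number from compound 3 to compound 4 (0.20 log units; within the scatter), so compounds 2, 3 and 4 are not separated. Compound 4 is a second case that clears nitro, with an at least 2.0-fold lower number from compound 1 to compound 4 (0.31 log units; beyond the scatter), though that size is only a floor: the limit of > 5000 nM in this assay, at which 1 of the 4 values shown sits.

Going by these compounds, whether an amine, a carboxylic acid or a longer chain at this position stays in the same range remains open. On these data alone, the actual number for compound 1 also remains open.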